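The compounds below may be only part of what the source reports. "The series", "measured", "known", "first", "only" and "open" are said of these compounds alone.

Measured so far:
Compound 1, `O=C(/C(=C\c1ccc(Cl)cc1Cl)Sc1ccc(Br)cc1)c1ccc(Br)cc1`, gives 1000 nM in a functional assay on DU-145 cells (Homo sapiens) for inhibition, read by trypan blue exclusion, with a stated time of 96 h; on this read-out lower numbers stand for stronger inhibition of growth and higher numbers for weaker inhibition of growth.
Compound 2, `Cc1ccc(S(=O)(=O)/C(=C/c2ccccc2F)C(=O)c2ccc(Cl)cc2)cc1`, gives 2500 nM in this assay.
Compound 3, `CN(C)c1ccc(/C=C(/SCc2ccc(F)cc2)C(=O)c2ccc(Cl)cc2)cc1`, gives 50000 nM in this assay.

Among these three numbers, compound 1 stands lowest, and its steps to both others lie beyond the usual scatter: compound 2 is the nearest, and compound 3 the furthest away. Compound 1 is therefore the most potent of the three in this assay.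

The unmeasured compound 4, `Nc1c(Br)cc(Br)cc1/C=C(/Sc1ccc(Br)cc1)C(=O)c1ccc(Br)cc1`, is built from compound 1 by a single replacement: 2-amino-3,5-dibromophenyl in place of 2,4-dichlorophenyl on a double-bonded chain carbon bound to a double-bonded chain carbon. The group that leaves carries two chlorine atoms and no hydrogen-bond donor or acceptor; the group that enters carries two bromine atoms together with one hydrogen-bond donor and one hydrogen-bond acceptor. Among the measured compounds shown here, no pair of measured compounds shows this change, so there is no directly comparable step to lean on.

The change is expected to leave the number roughly where compound 1 sits, perhaps drifting slightly toward weaker inhibition, with the step of a 1.5-fold higher number from compound 1 to compound 4 (0.18 log units; within the scatter) not clearly beyond the scatter. For compound 4 the estimate in this assay is 1500 nM, with a plausible range from 400 nM to 6000 nM.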

Compound 4, concentration for 50% growth inhibition: > 100000 nM
Compound 4: only a limit was reported (the forecaster's own chance of this, stated with the estimate: 5%); middle value at least 66-fold (1.82 log units) from the limit.
By their numbers in this assay, from the lowest: compound 1; then compound 2; then compound 3. At a limit, above all of these: compound 4.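

On the double-bonded chain carbon bound to a double-bonded chain carbon, the aryl group turns out to matter greatly: 2-amino-3,5-dibromophenyl in place of 2,4-dichlorophenyl gives an at least 100-fold higher number from compound 1 to compound 4 (2.00 log units; beyond the scatter) in this assay. Among the compounds shown here, the earlier compounds differ from one another in more than one place, so this is the first step that isolates a single position, and here the change all but removes growth inhibition. Compound 4 gives > 100000 nM, which is a limit of the assay and not a number, so the step has a floor but no known size: the limit of > 100000 nM in this assay, at which 1 of the 4 values shown sits.

This change swaps chlorine for bromine, shifts the halogen pattern and adds an amine all at once, and the compounds shown cannot separate these parts. A plain 3,5-dibromophenyl or 2-aminophenyl group at this place would show which part goes with the loss.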